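This account rests on a few compounds, and the source may have more. Where it says the series, first, only, none or still open, it means among the compounds named here.

The measured compounds:
compound 1, `Cc1ccc(CN2CCN(c3cccc4[nH]c(-c5ccc(C(C)(C)C)cc5)nc34)CC2)o1`, giving 705 nM in an assay on isolated protein for displacement of a labelled ligand from Gonadotropin-releasing hormone receptor (Homo sapiens); a higher number here means a weaker inhibitor, a lower number a stronger inhibitor
compound 2, `CCc1nc(C)c(CN2CCN(c3cccc4[nH]c(-c5ccc(C(C)(C)C)cc5)nc34)CC2)s1`, giving 20 nM in this assay
compound 3, `Cc1nc(CN2CCN(c3cccc4[nH]c(-c5ccc(C(C)(C)C)cc5)nc34)CC2)c(C)s1`, giving 21 nM in this assay

Compound 1 stands at the highest number of the three; the other two sit far beneath it, and compound 2 and compound 3 are within the scatter of one another. The unmeasured compound 4, `Cc1nc(CN2CCN(c3cccc4[nH]c(-c5ccc(C(C)(C)C)cc5)nc34)CC2)cn1C`, keeps the shared core and differs from compound 1 only in the group on the saturated chain carbon bound to the amine nitrogen in the ring: 1,2-dimethyl-1H-imidazol-4-yl in place of 5-methylfuran-2-yl on a saturated chain carbon bound to an amine nitrogen in a ring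

For the measured compounds named here, the steps that bear on this are a 35-fold lower number from compound 1 to compound 2 (1.55 log units; beyond the scatter) and a 34-fold lower number from compound 1 to compound 3 (1.53 log units; beyond the scatter), both large and both in the same direction, each swapping the 5-methylfuran-2-yl for a five-membered aromatic ring with two hetero atoms. On these data alone, the 1,2-dimethyl-1H-imidazol-4-yl also brings two hetero atoms and two hydrogen-bond acceptors, so a large downward step in this assay is expected, though the imidazole is untested here and the size carries more uncertainty. Compound 4 is therefore estimated at 40 nM, with a range from 10 nM to 160 nM, which would mean an expected step of an 18-fold lower number from compound 1 to compound 4 (1.25 log units; beyond the scatter).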

Compound 4, half-maximal inhibitory concentration: 10 nM
Beside the measured number, compound 4's estimate is 4.0-fold (0.60 log units) above it; low and high end bracket the measured number.
By their numbers in this assay, from the lowest: compounds 4, 2 and 3 (each within the scatter of the next, the first and the last beyond it); then compound 1.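

In this assay, 1,2-dimethyl-1H-imidazol-4-yl in place of 5-methylfuran-2-yl gives a 71-fold lower number from compound 1 to compound 4 (1.85 log units; beyond the scatter), so the large step is not confined to the two thiazoles: it also appears with a five-membered aromatic ring that holds 2 nitrogen hetero atoms and no sulfur. The three rings with 2 hetero atoms stay close together at this position, as a 2.0-fold lower number from compound 2 to compound 4 (0.30 log units; within the scatter) lies within the scatter, while a 2.1-fold lower number from compound 3 to compound 4 (0.32 log units; beyond the scatter) lies beyond it but is only modest. Nothing available explains why these rings differ so much from the furan.

On these data alone, it remains open whether the methyl groups on the imidazole are needed, since an unsubstituted imidazol-4-yl would test this. As far as these compounds go, it is also open whether a thiophene or a pyridine ring on this carbon would stand nearer to compound 1 or to compound 4.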